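Methyl for trifluoromethyl on the aryl of compound 1

The source may report more compounds than this note shows. Statements on the series, on what has been measured and on what is new or still open speak of the compounds shown alone.

Compound 1 `CCc1nc2c(-c3ccc(OC)nc3C(F)(F)F)ccnc2n1C(C)CC` gives 0.7 nM in an assay for binding affinity to Corticotropin releasing factor receptor (Rattus norvegicus) (on this read-out higher numbers stand for weaker inhibition and lower numbers for stronger inhibition), the lowest of the three numbers recorded. Compound 2 `CCc1nc2c(-c3ccc(OC)nc3C(F)(F)F)ccnc2n1C(C)C1CCC1` gives 0.8 nM, and a 1.1-fold higher number from compound 1 to compound 2 (0.06 log units; within the scatter) lies within the scatter. Compound 3 `CCCC(C)n1c(CC)nc2c(-c3ccc(OCC(=O)OCC)nc3C(F)(F)F)ccnc21` gives 1050 nM, which does not bear on the change at hand. Compound 4 `CCc1nc2c(-c3ccc(OC)nc3C)ccnc2n1C(C)CC` carries methyl in place of trifluoromethyl on an aromatic carbon. Going by the values given here, no measured step touches this position: the only step available, from compound 1 to compound 2, alters the group on the saturated chain carbon bound to the aromatic nitrogen and is within the scatter. With nothing directly comparable, the expected change for compound 4 is a modest weakening, a 2.9-fold higher number from compound 1 to compound 4 (0.46 log units; beyond the scatter). The estimated value for compound 4 is 2 nM, with a range from 0.5 nM to 10 nM.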

Compound 4, inhibition constant: 9.2 nM
Estimate against measurement, compound 4: 4.6-fold (0.66 log units) below; measured number inside the range.
By their numbers in this assay, from the lowest: compounds 1 and 2 (each within the scatter of the next); then compound 4; then compound 3.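

In this assay, going by these compounds alone, the aryl carbon next to the ring nitrogen proves sensitive to its substituent: methyl in place of trifluoromethyl gives a 13-fold higher number from compound 1 to compound 4 (1.12 log units; beyond the scatter) and is the first step beyond the scatter. Between these two groups, trifluoromethyl gives the lower number on the shared core. No measurement at hand accounts for this step.

Open, from the compounds shown here alone, is where a chlorine, an ethyl group or a nitrile would fall at this carbon. Also open, going by these compounds, is whether the step would carry over to the cyclobutyl-bearing chain of compound 2.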